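The source may hold more compounds than are shown below. What is called first, only, known or untested is meant among the compounds shown, and "the series" means these compounds.

Compound 1 `N#C/C(=C\N1CCN(C(=O)c2ccco2)C1=S)C(N)=O`: 300 nM
Compound 2 `O=CN1CCN(C(=O)c2ccco2)C1=S`: 13700 nM
Compound 3 `O=CN1CCN(c2ccc(Cl)c(Cl)c2)C1=S`: 17500 nM

In a functional assay on EKVX cells (Homo sapiens) for inhibition, read by sulforhodamine B assay, with a stated time of 48 h (on this read-out lower numbers stand for stronger inhibition of growth and higher numbers for weaker inhibition of growth), compound 1 stands lowest of the three numbers, and both of the other compounds lie beyond the scatter above it; compound 2 is the nearest and compound 3 the furthest. Compound 4 `N#C/C(=C\N1CCN(C(=O)c2ccco2)C1=S)C(=O)c1ccccc1` is the next compound and differs from compound 1 in one place: phenyl in place of amino on a carbonyl carbon. Within the data shown here, no measured pair shows this change, so its effect cannot be read from the data. The step is expected to be modest and towards a higher number, probably just beyond the scatter, as a 3.0-fold higher number from compound 1 to compound 4 (0.48 log units; beyond the scatter). Compound 4 is therefore estimated to give about 900 nM, with a range from 250 nM to 4000 nM.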

Compound 4, concentration for 50% growth inhibition: 17800 nM
Estimate against measurement, compound 4: 20-fold (1.30 log units) below; measured number outside the range, above it.
By their numbers in this assay, from the lowest: compound 1; then compounds 2, 3 and 4 (each within the scatter of the next).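

Phenyl in place of amino on a carbonyl carbon brings a 59-fold higher number from compound 1 to compound 4 (1.77 log units; beyond the scatter) in this assay and is a large step. This position therefore tolerates the change from carbamoyl to benzoyl poorly, and the rest of the structure, which the two compounds share, does not by itself secure the low number of compound 1.

From the compounds shown here alone, whether the low number depends on the amide hydrogen or on the absence of the phenyl ring stays open, as does the outcome with a methylamino group, a carboxylic acid or a methyl ketone at this carbon. No measurement at hand accounts for the size of this step.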